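A few compounds are considered here, and "the series" means these few. Any claim that something is new, unique, unknown or untested is made for them only; others in the source may bear on it.

Compound 1 `CCOC(=O)N1[C@@H]2C=C[C@@](OC)(C(=O)c3c2cc(OC)c(OC)c3OCC)N1C(=O)OCC`: > 300 ug/mL
Compound 2 `CCOC(=O)N1[C@@H]2C=C[C@@](OC)(C(=O)c3c2cc(OC)c(OC)c3OCc2ccccc2F)N1C(=O)OCC`: 99.7 ug/mL

Within the data shown here, in an ADME assay on KB cells (Homo sapiens) for cytotoxicity (on this read-out higher numbers stand for an effect only at larger amounts of compound and lower numbers for an effect already at smaller amounts), compound 2 gives 99.7 ug/mL, the only actual number so far. Compound 1 stands at > 300 ug/mL, which is a limit of the assay and not a number.

Compound 3 `CCOC(=O)N1[C@@H]2C=C[C@@](OC)(C(=O)c3c2cc(OC)c(OC)c3OCc2ccc(Cl)cc2)N1C(=O)OCC` carries 4-chlorophenyl in place of the 2-fluorophenyl of compound 2, on a saturated chain carbon bound to an oxygen on an aromatic ring (4-chlorophenyl in place of 2-fluorophenyl on a saturated chain carbon bound to an oxygen on an aromatic ring).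

Among the measured compounds shown here, only one measured step bears on this place: an at least 3.0-fold lower number from compound 1 to compound 2 (0.47 log units; beyond the scatter). For the measured compounds named here, that step replaced methyl with 2-fluorophenyl, a different kind of change, and no measured step exchanges one substituted phenyl for another. Compound 3 keeps a phenyl group there, so its number should stay close to that of compound 2 at 99.7 ug/mL.

The expected change is a 1.0-fold lower number from compound 2 to compound 3 (0.02 log units; within the scatter), so no step beyond the usual scatter is expected in this assay. For compound 3 the estimated value is 95 ug/mL, with an expected range from 35 ug/mL to 250 ug/mL.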

Compound 3, concentration for half-maximal effect: 99.9 ug/mL
For compound 3 the middle estimate is 1.1-fold (0.02 log units) below the measured one; low and high end bracket the measured number.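

In this assay, 4-chlorophenyl and 2-fluorophenyl on a saturated chain carbon bound to an oxygen on an aromatic ring cannot be told apart, with a 1.0-fold higher number from compound 2 to compound 3 (0.00 log units; within the scatter). The step away from methyl now holds for two different halogen-bearing phenyl groups, not just one, with an at least 3.0-fold lower number from compound 1 to compound 3 (0.47 log units; beyond the scatter). Compound 1 has no exact number, only a limit of the assay: the limit of > 300 ug/mL in this assay, at which 1 of the 3 values shown sits.

The step from compound 2 to compound 3 swaps the halogen and moves it on the ring in one go, so neither change can be read separately, and two phenyl groups are a narrow base for any pattern. Going by these compounds, whether a plain phenyl without a halogen, a longer chain or a group carrying an amine at this place would give a similar number remains open.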